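A few compounds are considered here, and "the series" means these few. Any claim that something is new, unique, unknown or untested is made for them only; others in the source may bear on it.

Compound 1 `CN(C)CCn1cnnc1-c1cc(Oc2ccc(NC(=O)N/N=C/c3ccc(O)c(Br)c3)cc2F)ccn1` gives 450 nM in a functional assay on HT-29 cells (Homo sapiens) for cytotoxicity, read by MTT assay, with a stated time of 72 h (a lower number here means a stronger inhibitor, a higher number a weaker inhibitor), and holds the lowest of the two numbers recorded so far; compound 2 `CN(C)CCn1cnnc1-c1cc(Oc2ccc(NC(=O)N/N=C/c3ccc(F)cc3F)cc2F)ccn1` gives 960 nM in this assay. Going by the values given here, the single step between measured compounds, a 2.1-fold higher number from compound 1 to compound 2 (0.33 log units; beyond the scatter), puts 2,4-difluorophenyl in place of 3-bromo-4-hydroxyphenyl on the carbon with a double bond to nitrogen, removing the bromo and the hydroxy together.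

Compound 3 `COc1cc(/C=N/NC(=O)Nc2ccc(Oc3ccnc(-c4nncn4CCN(C)C)c3)c(F)c2)ccc1O` has not yet been measured and differs from compound 1 by methoxy in place of bromo on an aromatic carbon. Among the compounds with values here, the hydroxy group stays and only the bromo is exchanged, so the step from compound 1 to compound 2 bears on it only in part: it shows that reworking the 3-bromo-4-hydroxyphenyl arm costs a modest amount, but no measured pair isolates the bromo on its own. The expectation is a step close to the scatter, if anything a small rise in the number, and compound 3 is expected to give about 600 nM, within 270 nM to 1300 nM. That estimate corresponds to an expected step of a 1.3-fold higher number from compound 1 to compound 3 (0.12 log units; within the scatter).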

Compound 3, half-maximal inhibitory concentration: 120 nM
Compound 3: the middle estimate sits 5.0-fold (0.70 log units) above what was measured; the whole stated range lies above it.
By their numbers in this assay, from the lowest: compound 3; then compound 1; then compound 2.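

In this assay the place held by the bromo in compound 1 now proves sensitive on its own: with the hydroxy group kept, methoxy in place of bromo gives a 3.8-fold lower number from compound 1 to compound 3 (0.57 log units; beyond the scatter) and stands beyond the scatter, whereas the earlier pair changed the bromo and the hydroxy together and could not separate them. Across the whole arm, 4-hydroxy-3-methoxyphenyl in place of 2,4-difluorophenyl gives an 8.0-fold lower number from compound 2 to compound 3 (0.90 log units; beyond the scatter) and widens the range seen in this series, leaving the 4-hydroxy-3-methoxyphenyl arm of compound 3 with the lowest number of the three. The compounds shown carry no supporting measurement that would account for the lower number with methoxy.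

On these data alone, whether the gain belongs to methoxy in particular or would also appear with an ethoxy, a chloro or an amino group on the same aromatic carbon remains open. Also open is what the hydroxy group contributes when the methoxy stays in place, since no compound shown changes the hydroxy alone.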